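Thiophene for Thiazole on an Aryloxyacetamide Core

The source may report more compounds than this note shows. Statements on the series, on what has been measured and on what is new or still open speak of the compounds shown alone.

Measured compounds:
compound 1, `Cc1ccc(OCC(=O)N(Cc2cccs2)C2CC2)cc1`: 8 nM
compound 2, `CCN(Cc1cncs1)C(=O)COc1ccc(C)cc1`: 1100 nM

In an assay on HEK293 cells for agonist activity at transient receptor potential cation channel subfamily M member 8 (Homo sapiens), read by fluorescence and calcium flux, with a stated time of 15 min (a higher number here means that more compound is needed for the effect, a lower number that less compound is needed), compound 2 gives 1100 nM, the highest of the two numbers; compound 1 gives 8 nM, a gap well beyond the scatter. Compound 3, `CCN(Cc1cccs1)C(=O)COc1ccc(C)cc1`, carries the change (thiophen-2-yl in place of 1,3-thiazol-5-yl on a saturated chain carbon bound to an amide-type nitrogen). For the measured compounds named here, compound 3 also shares its thiophen-2-ylmethyl group with compound 1, yet differs from it elsewhere, so no measured step isolates this change. A sizeable downward step in this assay is expected, a 9.2-fold lower number from compound 2 to compound 3 (0.96 log units; beyond the scatter), without reaching the level of compound 1. Compound 3 is estimated at 120 nM, within 25 nM to 600 nM.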

Compound 3, half-maximal effective concentration: 8 nM
Estimate against measurement, compound 3: 15-fold (1.18 log units) above; the measured number lies below the stated range.
By their numbers in this assay, from the lowest: compounds 1 and 3 (each within the scatter of the next); then compound 2.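

In this assay, for the compounds shown here, thiophen-2-yl in place of 1,3-thiazol-5-yl on a saturated chain carbon bound to an amide-type nitrogen gives a 140-fold lower number from compound 2 to compound 3 (2.14 log units; beyond the scatter), the first reading that isolates this change. Ethyl in place of cyclopropyl on an amide-type nitrogen gives no change at the digits printed from compound 1 to compound 3 (within the scatter), so with thiophen-2-yl present these two groups cannot be told apart here. Nothing shown explains the large step. Going by these compounds, whether cyclopropyl would match ethyl with 1,3-thiazol-5-yl present stays open, as does how a longer chain or an amine in place of ethyl would read.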